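A Side-Chain Swap Carried Over to a Second Core

The compounds below may be only part of what the source reports. "The series", "measured", "known", "first", "only" and "open" are said of these compounds alone.

Compound 1, `CC(O)n1cnc2c(N)nc(I)nc21`, in a functional assay on HEp-2 cells (Homo sapiens) for inhibition (a lower number here means a stronger inhibitor, a higher number a weaker inhibitor), gives only the limit > 500000 nM.
Compound 2, `Nc1nc(I)nc2c1ncn2OCCO`, in this assay gives only the limit > 500000 nM.
Compound 3, `CC(O)n1cnc2c(S)nc(F)nc21`, in this assay gives only the limit > 500000 nM.

The change from compound 1 to compound 2 is 2-hydroxyethoxy in place of 1-hydroxyethyl on an aromatic nitrogen. For the measured compounds named here, because both values are limits, the step that the two limits leave unreadable from compound 1 to compound 2 cannot be read, which is what the limit of > 500000 nM in this assay, at which 3 of the 3 values shown sit, states: every value seen so far sits at that same limit, so no step has yet been measured as a number.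

Compound 4, `OCCOn1cnc2c(S)nc(F)nc21`, has not been measured. It differs from compound 3 by 2-hydroxyethoxy in place of 1-hydroxyethyl on an aromatic nitrogen, the same change that turns compound 1 into compound 2. How the core of compound 3 differs from the core of compound 1 is not broken down here.

Going by the values given here, because compound 3 sits at the limit > 500000 nM and because the limit of > 500000 nM in this assay, at which 3 of the 3 values shown sit, shows all three values there, the expected step from compound 3 to compound 4 is a step that the limit leaves unreadable from compound 3 to compound 4, with no measured step to suggest otherwise. Compound 4 is therefore expected to give roughly 1000000 nM, most likely again reported only as a limit.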

Compound 4, half-maximal inhibitory concentration: > 500000 nM
Compound 4: no number, only a limit; the forecaster's own chance of this, stated with the estimate: 90%; the middle value does not contradict the limit.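

In this assay compound 4 gives > 500000 nM, a limit and not a number. Compound 3 also stands only at a limit, so the step between compound 3 and compound 4 cannot be read, and the same holds for all values so far: the limit of > 500000 nM in this assay, at which 4 of the 4 values shown sit.

The compounds shown leave open whether swapping 1-hydroxyethyl for 2-hydroxyethoxy changes inhibition at all.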